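A Nitro for a Hydroxy in a Series Sitting at Limits

The compounds below may be only part of what the source reports. "The series", "measured", "known", "first", "only" and "open" are said of these compounds alone.

Compound 3 `CC(C)N(Cc1cccc(OCCCCCC(=O)O)c1)C(=O)c1ccc(-c2cccc(O)c2)cc1` stands at a limit rather than a number: in an ADME assay on BJ cells (Homo sapiens) for cytotoxicity, read by CellTiter-Glo and resazurin assay, with a stated time of 72 h (a higher number here means that more compound is needed for the effect, a lower number that less compound is needed), compound 3 gives > 26000 nM. Compound 1 `CC(C)N(Cc1cccc(OCCCCCC(=O)O)c1)C(=O)c1ccc(-c2ccsc2)cc1` reaches the same limit, giving > 26000 nM in this assay. Compound 2 `CCOc1cccc(-c2ccc(C(=O)N(Cc3cccc(OCCCCCC(=O)O)c3)C(C)C)cc2)c1` also stops at a limit, giving > 20800 nM in this assay. All three values are limits, two at the limit of > 26000 nM in this assay, at which 2 of the 3 values shown sit, and one at the limit of > 20800 nM in this assay, at which 1 of the 3 values shown sits. The steps a step that the two limits leave unreadable from compound 1 to compound 2, a step that the two limits leave unreadable from compound 1 to compound 3 and a step that the two limits leave unreadable from compound 2 to compound 3 therefore carry no readable size; both ends of each lie at a limit. Compound 4 `CC(C)N(Cc1cccc(OCCCCCC(=O)O)c1)C(=O)c1ccc(-c2cccc([N+](=O)[O-])c2)cc1` differs from compound 3 by nitro in place of hydroxy on an aromatic carbon. Among the measured compounds shown here, no measured step bears on this change, and the three compounds already known give only limits. With every value shown at a limit, the step that the limit leaves unreadable from compound 3 to compound 4 in this assay is expected to stay within the scatter. Compound 4 is estimated at 30000 nM, within 15000 nM to 60000 nM, and most likely again only a limit is expected.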

Compound 4, half-maximal effective concentration: > 26000 nM
Compound 4 ended at the assay's limit; the forecaster's own chance of this, stated with the estimate: 80%; the middle value does not contradict the limit.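

Compound 4 also stops at a limit in this assay, so its steps from compound 1, compound 2 and compound 3 cannot be read, as each has a limit at both ends. The compounds shown leave open where the half-maximal effective concentration of any of them lies.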